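A few compounds are considered here, and "the series" means these few. Any claim that something is new, unique, unknown or untested is made for them only; others in the source may bear on it.

The measured compounds:
compound 1, `Cc1cc(C)cc(Oc2ccc3nc(COc4cccc(C(=O)O)c4)n(C)c3n2)c1`: 0.5 ug/mL
compound 2, `Cn1c(COc2cccc(C(=O)O)c2)nc2ccc(Oc3ccc(Cl)cn3)cc21`: 17 ug/mL

In a physicochemical assay for solubility, read by HPLC, measured as thermodynamic solubility, with a stated time of 4 h, at pH 6.8 (on this read-out higher numbers stand for higher solubility and lower numbers for lower solubility), compound 2 gives 17 ug/mL, the highest of the two numbers shown. Its nearest neighbour is compound 1, which gives 0.5 ug/mL, a gap that lies well beyond the usual scatter of this assay. Within the data shown here, no pair of measured compounds differs in only one place, so no measured step is available to guide the next comparison.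

Compound 3, `Cc1cc(F)cnc1Oc1ccc2nc(COc3cccc(C(=O)O)c3)n(C)c2c1`, is the unmeasured compound. It differs from compound 2 in one place: 5-fluoro-3-methylpyridin-2-yl in place of 5-chloropyridin-2-yl on an oxygen on an aromatic ring. The group that leaves and the group that enters are close in size and carry the same count of hydrogen-bond donors and acceptors, so the change is a small one.

Among the measured compounds shown here, with no measured step for a change of this kind, the expectation for compound 3 rests on the value of compound 2 alone. The step of a 1.5-fold lower number from compound 2 to compound 3 (0.19 log units; within the scatter) is expected to be modest, leaning toward somewhat lower solubility but possibly not beyond the scatter. Compound 3 is therefore estimated at 11 ug/mL, within a range from 3.5 ug/mL to 35 ug/mL.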

Compound 3, solubility: 14 ug/mL
Compound 3: middle estimate off by 1.3-fold (0.10 log units), on the low side, within the range that was stated.
By their numbers in this assay, from the lowest: compound 1; then compounds 3 and 2 (each within the scatter of the next).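

In this assay, among these compounds, 5-fluoro-3-methylpyridin-2-yl in place of 5-chloropyridin-2-yl on an oxygen on an aromatic ring gives a 1.2-fold lower number from compound 2 to compound 3 (0.08 log units; within the scatter) and supplies the first measured step at this place, where the earlier compounds offered none. The two groups differ by one heavy atom and in their halogen, and they carry the same counts of hydrogen-bond donors and acceptors, so this one exchange on the shared core leaves the read-out within its usual scatter. Nothing available explains why the two values stay so close, and no supporting measurement bears on the result.

The step combines two alterations, fluorine for chlorine and an added methyl group, and the compounds shown do not separate them, so the share of each remains unknown; 5-fluoropyridin-2-yl and 5-chloro-3-methylpyridin-2-yl would each isolate one. Nor do they show whether this place stays as quiet with a group of a different kind on the oxygen, such as a pyridine ring bearing an amine or a morpholine ring.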